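Methyl to Nitro: an Expected Shift in Cell Growth Inhibition

The source may report more compounds than this note shows. Statements on the series, on what has been measured and on what is new or still open speak of the compounds shown alone.

Compound 1, `CCn1c(/C=C2/C(=O)Nc3ccc(C)cc32)nc2ccccc21`, gives > 50000 nM in a functional assay on BT-549 cells (Homo sapiens) for cytotoxicity, read by MTT assay, with a stated time of 48 h; on this read-out higher numbers stand for weaker inhibition and lower numbers for stronger inhibition.
Compound 2, `CC(C)n1c(/C=C2/C(=O)Nc3ccc(Cl)cc32)nc2ccccc21`, gives 35100 nM in this assay.

For compound 1 the result is only a limit of the measurement, not a number, as noted in the limit of > 50000 nM in this assay, at which 1 of the 2 values shown sits. Compound 2, which differs from compound 1 in two places at once, gives a measured number, and the two values sit close enough to one another that no order between them can be read. Both compounds are therefore weak inhibitors in this assay, and compound 1 stands at the edge of what the measurement can report.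

Compound 3, `CCn1c(/C=C2/C(=O)Nc3ccc([N+](=O)[O-])cc32)nc2ccccc21`, has not yet been tested. It differs from compound 1 by nitro in place of methyl on an aromatic carbon. For the measured compounds named here, no measured pair shows what such a swap does here, so the expectation rests on the weak starting point alone: the step from compound 1 to compound 3 is expected to be an at least 1.6-fold lower number from compound 1 to compound 3 (0.22 log units; that floor lies within the scatter), modest and toward stronger inhibition, but with a real chance of no change beyond the scatter. Compound 3 is estimated at 30000 nM in this assay, within a range from 8000 nM to 100000 nM.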

Compound 3, half-maximal inhibitory concentration: > 50000 nM
Compound 3 ended at the assay's limit (the forecaster's own chance of this, stated with the estimate: 40%); middle value at least 1.6-fold (0.22 log units) from the limit.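

Compound 3, like compound 1, ended at a limit of the measurement rather than at a number, so no step between the two can be read: the limit of > 50000 nM in this assay, at which 2 of the 3 values shown sit.

On these data alone, whether nitro in place of methyl on an aromatic carbon changes the result in this assay therefore remains open.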